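The compounds below may be only part of what the source reports. "The series", "measured", "known", "first", "only" and "open" are said of these compounds alone.

Measured compounds in a physicochemical assay for lipophilicity, using the shake flask method, in phosphate buffer, measured as octanol-water partition, with a stated time of 30 min, at pH 7.4; on this read-out lower numbers stand for lower lipophilicity and higher numbers for higher lipophilicity:
compound 1, `Cn1cc(-c2cnc(NCc3c(F)ccc4c3CCO4)c3cn[nH]c(=O)c23)cn1`, gives 2.7
compound 2, `Cc1ncccc1-c1cnc(NCc2c(F)ccc3c2CCO3)c2nn(CC#N)c(=O)n12`, gives 2.2
compound 3, `COCCC(=O)Nc1cnc(NCc2c(F)ccc3c2CCO3)n2cnnc12`, gives 1.4

Of these three, compound 1 stands highest in this assay. The nearest number is that of compound 2, which lies lower by more than the usual scatter, and the number for compound 3 lies lower still, again beyond the scatter. Compound 4, `Cc1nn(C)cc1-c1cnc(NCc2c(F)ccc3c2CCO3)c2cn[nH]c(=O)c12`, differs from compound 1 by a single change: methyl in place of hydrogen on an aromatic carbon. Within the data shown here, no measured pair shows this exact change, so the step has to be estimated. A methyl entering for a hydrogen is expected to move the number upward by a small step, a number 0.40 log units higher from compound 1 to compound 4 (beyond the scatter), likely at or just beyond the scatter. Compound 4 is therefore expected to give about 3.1, in a range from 2.7 to 3.5.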

Compound 4, distribution coefficient: 2.8
Compound 4: middle estimate off by 0.30 log units, on the high side, and the stated range covers the measured number.
By their numbers in this assay, from the lowest: compound 3; then compound 2; then compounds 1 and 4 (each within the scatter of the next).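

Among these compounds, compound 1, compound 2 and compound 3 formed no pair differing in one place, so they said nothing about this position. In this assay, methyl in place of hydrogen on this aromatic carbon, turning 1-methyl-1H-pyrazol-4-yl into 1,3-dimethyl-1H-pyrazol-4-yl, gives a step of a number 0.10 log units higher from compound 1 to compound 4 (within the scatter) and thus no clear separation at this position. Nothing available accounts for this result. Still open, on these data alone, is how an ethyl, a methoxy or an amine would read on this same carbon. Also open, as far as these compounds go, is whether methyl gives a similar step on another core.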